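Small Chain Extensions on Two Related Cores

The source may report more compounds than this note shows. Statements on the series, on what has been measured and on what is new or still open speak of the compounds shown alone.

Compound 1, `CCCn1nc(-c2ccc(C(=O)OCC)cc2)c2ccccc21`, gives 490 nM in a functional assay on cells (Platelet, Homo sapiens) for inhibition; on this read-out higher numbers stand for weaker inhibition and lower numbers for stronger inhibition.
Compound 2, `CCCCn1nc(-c2ccc(C(=O)OCC)cc2)c2ccccc21`, gives 670 nM in this assay.
Compound 3, `CCNC(=O)c1ccc(-c2nn(Cc3ccccc3)c3ccccc23)cc1`, gives 5640 nM in this assay.

Compound 2 differs from compound 1 by methyl in place of hydrogen on a saturated chain carbon, three bonds along the chain from an aromatic nitrogen, and this gave a 1.4-fold higher number from compound 1 to compound 2 (0.14 log units; within the scatter). Compound 4, `CCCNC(=O)c1ccc(-c2nn(Cc3ccccc3)c3ccccc23)cc1`, differs from compound 3 by methyl in place of hydrogen on a saturated chain carbon, two bonds along the chain from an amide-type nitrogen. The two changes are the same kind of change, not the same: one sits three bonds along the chain from an aromatic nitrogen, the other two bonds along the chain from an amide-type nitrogen. The difference between the two cores is not broken down here. Compound 3 stands far weaker than compound 1 and compound 2 in this assay. Compound 4 is expected to show a 1.2-fold higher number from compound 3 to compound 4 (0.06 log units; within the scatter), resting on the small step of a 1.4-fold higher number from compound 1 to compound 2 (0.14 log units; within the scatter). Compound 4 is therefore estimated at 6500 nM, between 3000 nM and 14000 nM.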

Compound 4, half-maximal inhibitory concentration: > 10000 nM
Compound 4: a limit, no number; the forecaster's own chance of this, stated with the estimate: 5%; middle value at least 1.5-fold (0.18 log units) from the limit.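

Compound 4 gives > 10000 nM in this assay, and this value is a limit of the assay, not a number. Adding the methyl on a saturated chain carbon, two bonds along the chain from an amide-type nitrogen, gives an at least 1.7-fold higher number from compound 3 to compound 4 (0.24 log units; that floor lies within the scatter), so only a floor is known for the size of this step. This shows that the change did not bring a stronger reading on either core, but it does not show whether the change carries over with the same size from one core to the other: the same change on two cores in this assay, a 1.4-fold higher number (0.14 log units; within the scatter) from compound 1 to compound 2 and an at least 1.7-fold higher number (0.24 log units; that floor lies within the scatter) from compound 3 to compound 4; the limit leaves it open whether they differ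

On these data alone, what a longer chain would give on either core remains open. So does the effect of a carboxylic acid in place of the ester of compound 1.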